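The compounds below may be only part of what the source reports. "The series", "measured", "known", "first", "only" and "open" are said of these compounds alone.

Working notes on the series. Compound 1 `CN(C)c1ccc2nc(-c3c(Cl)nc(N)nc3N[C@@H]3C[C@H](CO)[C@@H](O)[C@H]3O)sc2c1`, compound 2 `Nc1ncc(-c2nc3ccccc3s2)c(N[C@@H]2C[C@H](CO)[C@@H](O)[C@H]2O)n1` and compound 3 `Cc1nc(NCC2CC2)nc(N[C@@H]2C[C@H](CO)[C@@H](O)[C@H]2O)c1-c1nc2ccccc2s1` have been run in an ADME assay on cells (Homo sapiens) for cytotoxicity, read by polymerase chain reaction, with a stated time of 3 days; on this read-out lower numbers stand for higher toxicity in this test and higher numbers for lower toxicity in this test; compound 4 `Cc1nc(Nc2ncco2)nc(N[C@@H]2C[C@H](CO)[C@@H](O)[C@H]2O)c1-c1nc2ccccc2s1` has not. In this assay compound 1 gives only a limit, > 25000 nM. In this assay compound 2 likewise gives only a limit, > 25000 nM. In this assay, within the data shown here, compound 3 gives 8000 nM, the only actual number among the three measured compounds. Among the measured compounds shown here, no two measured compounds differ in a single place, so no measured step is available to calibrate the change from compound 3 to compound 4. That change is 1,3-oxazol-2-yl in place of cyclopropylmethyl on a nitrogen on an aromatic ring. With nothing in the series to anchor a shift of this kind, the step from compound 3 to compound 4 is expected to be small, a 1.3-fold higher number from compound 3 to compound 4 (0.10 log units; within the scatter), and not beyond the usual scatter in either direction. Compound 4 is accordingly estimated at 10000 nM in this assay, with a range from 3000 nM to 30000 nM. A limit rather than a number remains a real possibility for compound 4 because of the limit of > 25000 nM in this assay, at which 2 of the 3 values shown sit.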

Compound 4, half-maximal cytotoxic concentration: > 25000 nM
Compound 4: no number, only a limit (the forecaster's own chance of this, stated with the estimate: 35%); middle value at least 2.5-fold (0.39 log units) from the limit.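

In this assay, among these compounds, the swap of cyclopropylmethyl for 1,3-oxazol-2-yl on a nitrogen on an aromatic ring gives an at least 3.1-fold higher number from compound 3 to compound 4 (0.49 log units; beyond the scatter), the only measured single-place step. This shows that the group on this nitrogen can by itself move the read-out beyond the scatter, in the direction of lower toxicity in this test. The value of compound 4 is a limit and not a number, so the step has a lower bound only and its full size stays unresolved: the limit of > 25000 nM in this assay, at which 3 of the 4 values shown sit.

On these data alone, whether the shift follows from the entry of 1,3-oxazol-2-yl or from the loss of cyclopropylmethyl stays open. The compounds shown also leave open how a phenyl ring or a longer alkyl chain on this nitrogen would read in this assay.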